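A few compounds are considered here, and "the series" means these few. Any claim that something is new, unique, unknown or untested is made for them only; others in the source may bear on it.

Of the compounds shown here, two have been measured so far. Compound 1 `ClCc1ccc(Cn2cnc3c(Cl)ncnc32)cc1` gives 24000 nM in a functional assay on SF-295 cells (Homo sapiens) for cytotoxicity, read by sulforhodamine B assay, with a stated time of 48 h (a lower number here means that less compound is tolerated, a higher number that more compound is tolerated), and compound 2 `ClCc1ccccc1Cn1cnc2c(Cl)nc(Cl)nc21` gives 6020 nM in this assay. Compound 2 therefore has the lower of the two numbers, and the gap between compound 1 and compound 2 lies beyond the usual scatter, so compound 2 is the one of which less is tolerated by the cells.

Compound 3 `ClCc1ccccc1Cn1cnc2c(Cl)ncnc21` is the next compound to be tested. It differs from compound 2 in one place: hydrogen in place of chloro on an aromatic carbon. Among the compounds with values here, no pair of measured compounds shows this change, so there is no measured step to lean on. Compound 3 is expected to give a number somewhat higher than compound 2, the step of a 2.0-fold higher number from compound 2 to compound 3 (0.30 log units; within the scatter) being modest and close to the edge of the scatter. The estimate for compound 3 in this assay is 12000 nM, with a range from 5000 nM to 30000 nM.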

Compound 3, concentration lethal to 50% of the cells: 51300 nM
The estimate for compound 3 lay 4.3-fold (0.63 log units) below the measured number; the measured number lies above the stated range.
By their numbers in this assay, from the lowest: compound 2; then compound 1; then compound 3.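

Replacing the chloro group on the aromatic carbon between two ring nitrogen atoms with hydrogen gives an 8.5-fold higher number from compound 2 to compound 3 (0.93 log units; beyond the scatter) in this assay. Within the data shown here, this is the first measured step at this position, and it shows that the loss of a single heavy atom there is enough to change, well beyond the scatter, how much compound the cells tolerate, with the chloro-bearing compound 2 being tolerated less. Nothing available explains why this one atom has so large an effect.

The compounds shown leave open how other groups on this carbon, such as an amine or a methoxy group, would compare with chloro and hydrogen. Going by these compounds, they also rest on one pair, so it remains open whether the same change would give a similar step on a different shared core.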